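Swapping an amine for a hydroxyl on a coumarin-derived hydrazone

The source may report more compounds than this note shows. Statements on the series, on what has been measured and on what is new or still open speak of the compounds shown alone.

Compound 1 `N/N=C\c1cc(=O)oc2cc(OCc3ccccc3)cc(OCc3ccccc3)c12` carries two benzyloxy groups; in a functional assay, read by spectrophotometry, with a stated time of 1 h (on this read-out higher numbers stand for weaker inhibition and lower numbers for stronger inhibition), compound 1 gives only the assay limit > 2000000 nM. Compound 3 `O=c1cc(/C=N\Nc2ccc([N+](=O)[O-])cc2[N+](=O)[O-])c2c(OCc3ccccc3)cc(OCc3ccccc3)cc2o1` is made from it by placing 2,4-dinitrophenyl in place of hydrogen on an amine nitrogen, and compound 3 gives 734000 nM, which is an at least 2.7-fold lower number from compound 1 to compound 3 (0.43 log units; beyond the scatter). Compound 2 `N/N=C\c1cc(=O)oc2cc(OCc3ccccc3)ccc12` has one benzyloxy group and is reported in this assay as "not active" (no number reported), with no number attached. Compound 4 `O=c1cc(/C=N\O)c2ccc(OCc3ccccc3)cc2o1` differs from compound 2 by hydroxy in place of amino on a double-bonded nitrogen. Going by the values given here, no measured step changes a hydrazone nitrogen in this way, so no size can be inferred; the weak results so far, including (the limit of > 2000000 nM in this assay, at which 1 of the 3 values shown sits), suggest compound 4 is expected to remain weak, estimated at 1500000 nM (range 300000 nM to 5000000 nM).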

Compound 4, half-maximal inhibitory concentration: > 2000000 nM
Compound 4 gave a limit, no number (the forecaster's own chance of this, stated with the estimate: 55%); middle value at least 1.3-fold (0.12 log units) away from the limit.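

Compound 4 gives only an assay limit, > 2000000 nM. Going by these compounds alone, compound 2 has no number, so no step from compound 2 to compound 4 can be read. On these data alone, whether hydroxy in place of amino changes inhibition at all stays open.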